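A few compounds are considered here, and "the series" means these few. Any claim that something is new, unique, unknown or untested is made for them only; others in the source may bear on it.

Compound 1 `COc1ccc(Nc2ccc3c(c2)C(=O)N(C2CCC(=O)NC2=O)C3=O)cc1` and compound 2 `CC(=O)c1ccc(Nc2cccc3c2C(=O)N(C2CCC(=O)NC2=O)C3=O)cc1` share a core but differ in two places at once: in the group carried on the outer six-membered ring and in the point at which that ring is joined to the core. In an assay on FRT-Jurkat cells for inhibition of nuclear factor NF-kappa-B complex (Homo sapiens), read by flow cytometry, with a stated time of 24 h, tested at 10 uM (on this read-out higher numbers stand for more inhibition at the one concentration tested (going by the name of the read-out) and lower numbers for less inhibition), compound 1 gives 29%, and compound 2 gives 2%. Among the measured compounds shown here, compound 1 thus stands highest of the two numbers measured so far, with compound 2 a distance below it that is beyond the usual scatter. Compound 3 `CC(C)c1ccc(Nc2ccc3c(c2)C(=O)N(C2CCC(=O)NC2=O)C3=O)cc1` keeps the core and the attachment of compound 1 and alters only the group on the outer ring: isopropyl in place of methoxy on an aromatic carbon. For the measured compounds named here, no measured pair isolates this single change, so nothing in the numbers ties it to a shift in this assay. The expected shift is therefore modest, a number 4 percentage points lower from compound 1 to compound 3 (within the scatter), within the scatter and without a clear direction. Compound 3 is estimated to give 25%, with a range of 5% to 50%.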

Compound 3, a percentage reported as inhibition, at one concentration (the size of the read-out at that concentration, not a potency): 11%
For compound 3 the middle estimate is 14 percentage points above the measured one; low and high end bracket the measured number.
By their numbers in this assay, from the lowest: compounds 2 and 3 (each within the scatter of the next); then compound 1.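

Among the compounds shown here, this is the first comparison in which only one place changes: on an aromatic carbon of the outer ring, para to a large group, isopropyl in place of methoxy gives a number 18 percentage points lower from compound 1 to compound 3 (beyond the scatter) in this assay. For the compounds shown here, with the shared core and its point of attachment held fixed, the group at this position alone is enough to move the read-out, and methoxy is the one of these two groups that goes with more inhibition at the single concentration tested. Nothing at hand explains why this swap lowers the number.

The compounds shown carry only methoxy and isopropyl at this position, so how an amine, a carboxylic acid or a longer chain there would compare stays open. Also open, going by these compounds, is how much of the gap to compound 2 comes from its acetyl group and how much from its different point of attachment, since those two differences are never separated.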